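The source may report more compounds than this note shows. Statements on the series, on what has been measured and on what is new or still open speak of the compounds shown alone.

The measured compounds:
Compound 1 `O=C(Nc1ccc(-c2cnc3cc(N4CCN(C5CC5)CC4)ccn23)cc1)c1ccc([N+](=O)[O-])o1` gives 1920 nM in a functional assay on AGS cells (Homo sapiens) for antiproliferative activity, read by CCK-8 assay, with a stated time of 72 h; on this read-out higher numbers stand for weaker inhibition and lower numbers for stronger inhibition.
Compound 2 `CN1CCCN(c2ccn3c(-c4ccc(NC(=O)c5ccc([N+](=O)[O-])o5)cc4)cnc3c2)CC1` gives 2700 nM in this assay.
Compound 3 `COc1ccn2c(-c3ccc(NC(=O)c4ccc([N+](=O)[O-])o4)cc3)cnc2c1` gives 720 nM in this assay.

Compound 3 gives the lowest of the three numbers: the step of a 2.7-fold lower number from compound 1 to compound 3 (0.43 log units; beyond the scatter) and the step of a 3.8-fold lower number from compound 2 to compound 3 (0.57 log units; beyond the scatter) both lie beyond the scatter, whereas a 1.4-fold higher number from compound 1 to compound 2 (0.15 log units; within the scatter) does not. Compound 4 `COc1ccn2c(-c3ccc(NC(=O)c4ccc([N+](=O)[O-])o4)cc3C)cnc2c1` differs from compound 3 by methyl in place of hydrogen on an aromatic carbon. Within the data shown here, none of the measured steps touches this change; each of them swaps the group on the shared core instead, so no measured step bears directly on it. One therefore expects no step beyond the scatter in this assay, and estimates the change no change at the digits printed from compound 3 to compound 4 (within the scatter). Compound 4 is expected to give 720 nM in this assay, between 300 nM and 1700 nM.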

Compound 4, half-maximal inhibitory concentration: 640 nM
Beside the measured number, compound 4's estimate is 1.1-fold (0.05 log units) above it; low and high end bracket the measured number.
By their numbers in this assay, from the lowest: compounds 4 and 3 (each within the scatter of the next); then compounds 1 and 2 (each within the scatter of the next).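

In this assay, methyl in place of hydrogen on an aromatic carbon of the six-membered aromatic ring of carbon only, ortho to a large group, gives a 1.1-fold lower number from compound 3 to compound 4 (0.05 log units; within the scatter). Among these compounds, this shows that this carbon can carry a methyl without a step beyond the scatter, something the earlier compounds could not show, as they differ only in the group on the shared core. Nothing measured here gives a reason for this result.

From the compounds shown here alone, whether an ethyl, a methoxy or an amine on this carbon would also stay within the scatter remains open. So does whether the methyl would give the same result alongside the 4-cyclopropylpiperazin-1-yl group of compound 1.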